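From methoxymethyl to pyridin-2-yl on a carbonyl carbon

The compounds below may be only part of what the source reports. "The series", "measured", "known", "first", "only" and "open" are said of these compounds alone.

Values in a functional assay on A2780 cells (Homo sapiens) for antiproliferative activity, read by CellTiter-Glo, with a stated time of 4 days (on this read-out higher numbers stand for weaker inhibition and lower numbers for stronger inhibition), are as follows:
compound 1 `CCC(=O)N[C@@H](C)c1ccc(NC(=O)NCc2cccnc2)cc1` gives 340 nM
compound 2 `CCC(=O)NC(C)(C)c1ccc(NC(=O)[C@H]2C[C@@H]2c2cccnc2)cc1` gives 832 nM
compound 3 `COCC(=O)N[C@@H](C)c1ccc(NC(=O)[C@H]2C[C@@H]2c2cccnc2)cc1` gives 30 nM

Of these three, compound 3 at 30 nM has the lowest number and so the strongest inhibition, well clear of the other two. The next compound to be tested, compound 4 `C[C@H](NC(=O)c1ccccn1)c1ccc(NC(=O)[C@H]2C[C@@H]2c2cccnc2)cc1`, differs from compound 3 in one place: pyridin-2-yl in place of methoxymethyl on a carbonyl carbon.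

Within the data shown here, only one measured step bears on this change, and it is large: a 28-fold lower number from compound 2 to compound 3 (1.44 log units; beyond the scatter). That step exchanges a whole side group containing this carbonyl. It shows that this part of the molecule can move the number strongly in this assay, but it says nothing about a ring here. Among the measured compounds shown here, no measured compound carries a ring on that carbonyl, so the direction stays open and the range has to be wide on both sides. The best guess is therefore no shift beyond the scatter, and the expected step is a 1.2-fold lower number from compound 3 to compound 4 (0.08 log units; within the scatter) in this estimate. For compound 4 the estimated value is 25 nM with an expected range from 6 nM to 100 nM in this test.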

Compound 4, half-maximal inhibitory concentration: 14 nM
Compound 4: middle estimate off by 1.8-fold (0.25 log units), on the high side; the range from low to high includes it.
By their numbers in this assay, from the lowest: compound 4; then compound 3; then compound 1; then compound 2.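

In this assay, putting pyridin-2-yl in place of methoxymethyl on this carbonyl carbon gives a 2.1-fold lower number from compound 3 to compound 4 (0.33 log units; beyond the scatter) and so moves the number in the direction of stronger inhibition, by a modest step. The earlier step from compound 2 to compound 3 exchanged a whole side group and said nothing about a ring here, whereas this pair shows that an aromatic ring on this carbonyl is compatible with low-nanomolar inhibition, and that it does slightly better than the open chain it replaces, even though the two groups have the same count of hydrogen-bond acceptors. Nothing measured for these compounds speaks to why the number shifts.

The compounds shown leave open whether the ring nitrogen itself matters, since a plain phenyl group on the same carbonyl carbon would be needed to separate the effect of the ring from that of its nitrogen. They also leave open how a pyridin-3-yl ring or a saturated ring such as cyclohexyl would compare at this place.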